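Capping a hydroxymethyl: from compound 2 to compound 3

The source may hold more compounds than are shown below. What is called first, only, known or untested is meant among the compounds shown, and "the series" means these compounds.

Measured compounds:
compound 1, `CCOC(=O)c1c(C)coc1-c1ccc2c(CC)cccc2c1OC`: 2.2 ug/mL
compound 2, `CCc1cccc2c(OC)c(-c3occ(C)c3CO)ccc12`: 7.1 ug/mL

Both were tested in a functional assay on KB cells (Homo sapiens) for cytotoxicity, read by MTT assay, with a stated time of 72 h; on this read-out lower numbers stand for an effect already at smaller amounts and higher numbers for an effect only at larger amounts of compound. Among the compounds with values here, compound 2 has the highest of the two numbers; its only neighbour is compound 1, with a lower number. Within the data shown here, the one measured step, a 3.2-fold higher number from compound 1 to compound 2 (0.51 log units; beyond the scatter), touches the same part of the shared core where the next change sits, but it swaps a whole group rather than capping the hydroxyl.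

Compound 3, `CCc1cccc2c(OC)c(-c3occ(C)c3COCC(F)(F)F)ccc12`, differs from compound 2 by 2,2,2-trifluoroethyl in place of hydrogen on an oxygen on a saturated carbon. Among the measured compounds shown here, no measured step covers this change directly, so the step from compound 2 is uncertain. The measured pair shows only that altering this position moves the number modestly, so compound 3 is expected to stay near compound 2, with a leaning toward the lower number of compound 1 because of a 3.2-fold higher number from compound 1 to compound 2 (0.51 log units; beyond the scatter). The expected step is a 1.8-fold lower number from compound 2 to compound 3 (0.25 log units; within the scatter). Compound 3 is estimated at 4 ug/mL, ranging from 1.5 ug/mL to 11 ug/mL.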

Compound 3, concentration for half-maximal effect: 6.6 ug/mL
The estimate for compound 3 lay 1.7-fold (0.22 log units) below the measured number, within the range that was stated.
By their numbers in this assay, from the lowest: compound 1; then compounds 3 and 2 (each within the scatter of the next).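

In this assay, replacing the hydrogen on the oxygen with 2,2,2-trifluoroethyl gives a 1.1-fold lower number from compound 2 to compound 3 (0.03 log units; within the scatter), so this read-out does not separate the free hydroxymethyl from its capped form. Within the data shown here, this is the first sign that a free hydroxyl hydrogen at this position is not needed to reach the number seen with compound 2. The ethoxycarbonyl compound remains apart from both: the change to the capped side chain gives a 3.0-fold higher number from compound 1 to compound 3 (0.48 log units; beyond the scatter), and the gap stays beyond the scatter whether the hydroxyl is free or capped, though the data available here offer no explanation for either result.

A single fluorinated cap cannot show whether the fluorine atoms matter, and a plain ethyl on the same oxygen would be the direct comparison for that question. Going by these compounds, it also remains open how this position would respond to an amine or a carboxylic acid in place of the hydroxymethyl, or to a longer chain on the oxygen.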